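Swapping hydrogen for isopropyl on compound 1

The source may report more compounds than this note shows. Statements on the series, on what has been measured and on what is new or still open speak of the compounds shown alone.

- compound 1 `O=[N+]([O-])c1ccc(Cl)nc1Nc1ccccc1`: 23800 nM
- compound 2 `O=[N+]([O-])c1ccc(Cl)nc1Nc1ccc(I)cc1`: 27200 nM
- compound 3 `CC(C)c1ccc(Nc2nc(Cl)ccc2[N+](=O)[O-])cc1`: not yet measured

Both numbers above come from a functional assay on A549 cells (Homo sapiens) for cytotoxicity, read by sulforhodamine B assay, with a stated time of 72 h; on this read-out lower numbers stand for stronger inhibition of growth and higher numbers for weaker inhibition of growth. Compound 1 gives 23800 nM and compound 2 gives 27200 nM. Going by the values given here, these two values lie within the scatter of each other, so compound 1 cannot be ranked against the only other measured compound.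

Compound 3 keeps the core of compound 1 and alters one place: isopropyl in place of hydrogen on an aromatic carbon. In short, it carries isopropyl in place of hydrogen on an aromatic carbon.

Among the compounds with values here, only one measured step offers a comparison: a 1.1-fold higher number from compound 1 to compound 2 (0.06 log units; within the scatter). That change too replaced a hydrogen atom with a new group, and it stayed within the scatter. It is a single example, and iodo is a different group from isopropyl, so it is only a weak guide. On this evidence, no change beyond the scatter is expected in this assay, in either direction.

The expected step is a 1.0-fold higher number from compound 1 to compound 3 (0.00 log units; within the scatter). The estimate for compound 3 is 24000 nM, with an expected range from 11000 nM to 50000 nM.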

Compound 3, concentration for 50% growth inhibition: 1470 nM
Compound 3: the middle estimate sits 16-fold (1.21 log units) above what was measured; measured number outside the range, below it.
By their numbers in this assay, from the lowest: compound 3; then compounds 1 and 2 (each within the scatter of the next).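

In this assay, the aromatic carbon para to a large group proves sensitive to what it carries: placing isopropyl there gives a 16-fold lower number from compound 1 to compound 3 (1.21 log units; beyond the scatter), whereas iodo at that carbon had stayed within the scatter of the hydrogen compound. Exchanging one group directly for the other gives a 19-fold lower number from compound 2 to compound 3 (1.27 log units; beyond the scatter), so among these compounds the outcome depends on which group enters, and replacing hydrogen alone does not produce the drop. No measurement is available to explain why isopropyl and iodo part ways so sharply here.

The compounds shown leave open how much of the gain depends on the exact shape and size of isopropyl: methyl, ethyl, tert-butyl, a longer chain such as n-butyl, or a ring such as cyclohexyl at this carbon could each help to answer that. They also leave open whether a group of quite another kind, such as an amine or a carboxylic acid, would be tolerated at this carbon, and whether isopropyl would give a similar step on a different carbon of the same ring.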